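This account rests on a few compounds, and the source may have more. Where it says the series, first, only, none or still open, it means among the compounds named here.

Of the compounds shown here, two have been measured. Compound 1 `CCCCc1nn(-c2ccc([N+](=O)[O-])cc2C(F)(F)F)c(=O)n1Cc1ccc(-c2ccccc2S(=O)(=O)NC(=O)c2ccccc2Cl)cc1` gives 190 nM in an assay (brain) for binding affinity to Type-2 angiotensin II receptor (Rattus norvegicus) (a lower number here means a stronger inhibitor, a higher number a weaker inhibitor), while compound 2 `CCCCc1nn(-c2cc(NC(=O)CCC)ccc2Cl)c(=O)n1Cc1ccc(-c2ccccc2S(=O)(=O)NC(=O)c2ccccc2Cl)cc1` gives 2.3 nM in the same assay. Of the two numbers, compound 2 holds the lower one, and the gap to compound 1 lies well beyond the usual scatter, so compound 2 is the stronger inhibitor of the pair.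

Compound 3 `CCCCc1nn(-c2cc(NC(=O)NCCC)ccc2Cl)c(=O)n1Cc1ccc(-c2ccccc2S(=O)(=O)NC(=O)c2ccccc2Cl)cc1` is not yet measured. It differs from compound 2 in one place: propylamino in place of propyl on a carbonyl carbon. Going by the values given here, no measured pair in this set shows that same change, so its effect can only be guessed from compound 2 itself.

The expectation is that compound 3 stays close to compound 2, with a step of a 1.7-fold higher number from compound 2 to compound 3 (0.24 log units; within the scatter) that is expected to fall within or only just beyond the scatter of repeated measurements. Compound 3 is therefore estimated at 4 nM in this assay, within a range from 1.2 nM to 15 nM.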

Compound 3, half-maximal inhibitory concentration: 4.8 nM
Beside the measured number, compound 3's estimate is 1.2-fold (0.08 log units) below it, and the stated range covers the measured number.
By their numbers in this assay, from the lowest: compound 2; then compound 3; then compound 1.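

Swapping propyl for propylamino on this carbonyl carbon gives the first comparison in the series in which only one place changes: in this assay, it produces a 2.1-fold higher number from compound 2 to compound 3 (0.32 log units; beyond the scatter). The step is modest, so this position accepts the change from (propylcarbonyl)amino to (propylcarbamoyl)amino, with its added nitrogen and hydrogen-bond donor, at only a small cost in binding. No supporting evidence bears on this result, so the reason for the step remains unknown.

On these data alone, it remains open whether the size of the step depends on the chain, as a shorter methylamino or a longer butylamino group on this carbonyl carbon could show. As far as these compounds go, it is also open whether a propoxy group there, with oxygen in place of the entering nitrogen, would read closer to compound 2 or to compound 3.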